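The source may hold more compounds than are shown below. What is called first, only, known or untested is meant among the compounds shown, and "the series" means these compounds.

In a functional assay on U-937 cells (Homo sapiens) for antiproliferative activity, read by MTT assay, with a stated time of 72 h (a lower number here means a stronger inhibitor, a higher number a weaker inhibitor), compound 2 (`Nc1ccccc1NC(=O)CCCCCCc1nc(-c2ccccc2)no1`) gives 730 nM and compound 1 (`Cc1ccc(-c2noc(CCCCCCC(=O)NO)n2)cc1`) gives 1360 nM, two values within the usual scatter of each other. Compound 3 (`Cc1ccc(-c2noc(CCCCCCC(=O)Nc3ccccc3N)n2)cc1`) differs from compound 2 in one place, with methyl in place of hydrogen on an aromatic carbon, turning phenyl into 4-methylphenyl: methyl in place of hydrogen on an aromatic carbon. Among the compounds with values here, no measured pair shows this change alone, so no step beyond the scatter is expected in this assay, in either direction. The expected change is a 1.0-fold higher number from compound 2 to compound 3 (0.01 log units; within the scatter). For compound 3 the estimate is 750 nM, with an expected range from 320 nM to 1700 nM.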

Compound 3, half-maximal inhibitory concentration: 460 nM
Compound 3: the middle estimate sits 1.6-fold (0.21 log units) above what was measured, within the range that was stated.
By their numbers in this assay, from the lowest: compounds 3, 2 and 1 (each within the scatter of the next, the first and the last beyond it).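

In this assay, methyl in place of hydrogen on the aromatic carbon, turning phenyl into 4-methylphenyl, gives a 1.6-fold lower number from compound 2 to compound 3 (0.20 log units; within the scatter) and so leaves no readable change at this position. Within the data shown here, with the 4-methylphenyl kept, 2-aminophenyl in place of hydroxy on the amide-type nitrogen gives a 3.0-fold lower number from compound 1 to compound 3 (0.47 log units; beyond the scatter) as the one step here that clears the scatter, though only modestly. No measurement at hand accounts for either step. Still open, as far as these compounds go, is whether methoxy, chloro or trifluoromethyl in place of the methyl would move the number. From the compounds shown here alone, a longer or shorter chain in place of the present one also remains open.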